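Replacing the 4-Methoxyphenyl Group with Cyclopent-1-en-1-yl

A few compounds are considered here, and "the series" means these few. Any claim that something is new, unique, unknown or untested is made for them only; others in the source may bear on it.

Three compounds have been measured in an assay on isolated protein for antagonist activity at prostaglandin E2 receptor EP1 subtype (Homo sapiens), read by reporter gene assay; on this read-out higher numbers stand for weaker inhibition and lower numbers for stronger inhibition:
compound 1 `O=C(O)c1csc(-n2nc(-c3cccc(F)c3)c3ccccc32)n1` gives 20 nM
compound 2 `O=C(O)c1csc(-n2nc(-c3ccc(Cl)cc3)c3ccccc32)n1` gives 12 nM
compound 3 `COc1ccc(-c2nn(-c3nc(C(=O)O)cs3)c3ccccc23)cc1` gives 4 nM

Compound 3 stands at the lowest number of the three. Compound 2 sits a modest step above it, a 3.0-fold lower number from compound 2 to compound 3 (0.48 log units; beyond the scatter), and compound 1 somewhat further, a 5.0-fold lower number from compound 1 to compound 3 (0.70 log units; beyond the scatter). Compound 4 `O=C(O)c1csc(-n2nc(C3=CCCC3)c3ccccc32)n1` differs from compound 3 by cyclopent-1-en-1-yl in place of 4-methoxyphenyl on an aromatic carbon. Each measured step swapped one substituent on the aromatic ring for another: a 1.7-fold lower number from compound 1 to compound 2 (0.22 log units; within the scatter) stayed within the scatter, while a 5.0-fold lower number from compound 1 to compound 3 (0.70 log units; beyond the scatter) and a 3.0-fold lower number from compound 2 to compound 3 (0.48 log units; beyond the scatter) were modest. None removed the aromatic ring itself, so they bear only loosely on this change; they suggest that alterations at this position shift this assay by modest amounts. Removing the ring is a larger change, and a higher number is expected, a 7.5-fold higher number from compound 3 to compound 4 (0.88 log units; beyond the scatter). Compound 4 is therefore estimated at 30 nM, with a range from 8 nM to 150 nM.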

Compound 4, half-maximal inhibitory concentration: 80 nM
Estimate against measurement, compound 4: 2.7-fold (0.43 log units) below; measured number inside the range.
By their numbers in this assay, from the lowest: compound 3; then compounds 2 and 1 (each within the scatter of the next); then compound 4.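

Cyclopent-1-en-1-yl, which has no aromatic ring, still gives a measurable reading at this position, but it gives a higher number than each aryl group shown: a 20-fold higher number from compound 3 to compound 4 (1.30 log units; beyond the scatter) is a large step, while a 6.7-fold higher number from compound 2 to compound 4 (0.82 log units; beyond the scatter) and a 4.0-fold higher number from compound 1 to compound 4 (0.60 log units; beyond the scatter) are modest ones. The cost of this swap therefore depends on which aryl group it replaces, and it is largest for 4-methoxyphenyl. Nothing available explains this loss of inhibition. Still open, going by these compounds, is how plain phenyl, saturated cyclopentyl or cyclohexenyl would compare at this position.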